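Imidazolyl for pyridyl on the chlorophenyl arm of compound 1

This account rests on a few compounds, and the source may have more. Where it says the series, first, only, none or still open, it means among the compounds named here.

Measured compounds:
compound 1 `Cn1nc2c(=O)n(CC3(O)CCN(Cc4ccc(-c5ccncc5)cc4Cl)CC3)cnc2c1-c1ccc(CN)cc1` 257 nM
compound 2 `CC(C)NCc1ccc(-c2c3ncn(CC4(O)CCN(Cc5ccc(-c6ccco6)cc5Cl)CC4)c(=O)c3nn2C)cc1` 29.1 nM
compound 3 `CCNCc1ccc(-c2c3ncn(CC4(O)CCN(Cc5ccc(-c6ccco6)cc5Cl)CC4)c(=O)c3nn2C)cc1` 15.2 nM

In an assay on isolated protein for inhibition of ubiquitin carboxyl-terminal hydrolase 7 (Homo sapiens), with stated times of 30 min and 2 h (on this read-out lower numbers stand for stronger inhibition and higher numbers for weaker inhibition), compound 1 gives the highest number of the three, with compound 2 the nearest and compound 3 the furthest. Compound 4 `Cn1nc2c(=O)n(CC3(O)CCN(Cc4ccc(-n5ccnc5)cc4Cl)CC3)cnc2c1-c1ccc(CN)cc1` is the untested member of this set; it differs from compound 1 by 1H-imidazol-1-yl in place of pyridin-4-yl on an aromatic carbon. Among the measured compounds shown here, the only measured step, a 1.9-fold lower number from compound 2 to compound 3 (0.28 log units; within the scatter), concerns the amine substituent rather than the aryl group on the chlorophenyl ring, so it offers no direct guide to this change. For the measured compounds named here, with no step bearing on the aryl exchange, the expectation for compound 4 is a number close to that of compound 1, a 1.0-fold higher number from compound 1 to compound 4 (0.01 log units; within the scatter), with no step beyond the scatter. The estimate for compound 4 in this assay is therefore 260 nM, expected between 90 nM and 750 nM.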

Compound 4, half-maximal inhibitory concentration: 228 nM
Estimate against measurement, compound 4: 1.1-fold (0.06 log units) above; measured number inside the range.
By their numbers in this assay, from the lowest: compounds 3 and 2 (each within the scatter of the next); then compounds 4 and 1 (each within the scatter of the next).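

In this assay, replacing pyridin-4-yl with 1H-imidazol-1-yl gives a 1.1-fold lower number from compound 1 to compound 4 (0.05 log units; within the scatter), the first step shown at this aromatic carbon. At this position, para to a large group, a five-membered aromatic ring with 2 hetero atoms and a six-membered aromatic ring with 1 hetero atom therefore cannot be told apart. Nothing available explains this match. The compounds shown leave open how a phenyl ring or a morpholine would read on this carbon. They also leave open whether the two rings would still match with an ethylaminomethyl group in place of the aminomethyl group.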